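Thioether ring swap in a cytotoxicity series on HT-29 cells

A few compounds are considered here, and "the series" means these few. Any claim that something is new, unique, unknown or untested is made for them only; others in the source may bear on it.

Measured compounds:
compound 1 `Cn1nnnc1SCC(=O)Nc1ccc(-c2nc(-c3ccccc3)c(-c3ccccc3)n2C)cc1`, 38%
compound 2 `Cn1c(-c2ccc(NC(=O)CSC3=NCCS3)cc2)nc(-c2ccccc2)c1-c1ccccc1`, 16.8%

In a functional assay on HT-29 cells (Homo sapiens) for cytotoxicity, read by MTT assay, with a stated time of 24 h, tested at 0.64 ug/mL (on this read-out lower numbers stand for a weaker effect and higher numbers for a stronger effect at the one concentration tested), compound 2 gives 16.8%, the lower of the two numbers; compound 1 gives 38%, and the step of a number 21.2 percentage points lower from compound 1 to compound 2 (beyond the scatter) sets them apart. Compound 3 `Cn1ccnc1SCC(=O)Nc1ccc(-c2nc(-c3ccccc3)c(-c3ccccc3)n2C)cc1` is not yet measured. It differs from compound 2 by a group of 6 heavy atoms (4 carbon, 2 nitrogen; one five-membered aromatic ring with 2 hetero atoms) in place of a group of 5 heavy atoms (3 carbon, 1 nitrogen, 1 sulfur; one five-membered non-aromatic ring with 2 hetero atoms), on a sulfur. Among the measured compounds shown here, the one measured step bears on it: when the aromatic ring left in favour of the non-aromatic ring, the read-out fell a number 21.2 percentage points lower from compound 1 to compound 2 (beyond the scatter). Restoring an aromatic ring is therefore expected to raise the read-out, by about a number 13.2 percentage points higher from compound 2 to compound 3 (beyond the scatter). Compound 3 is estimated at 30%, within 15% to 45%.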

Compound 3, a percentage reported as activity, at one concentration (the size of the read-out at that concentration, not a potency): 13.6%
For compound 3 the middle estimate is 16.4 percentage points above the measured one; measured number below the stated range.
By their numbers in this assay, from the lowest: compounds 3 and 2 (each within the scatter of the next); then compound 1.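

In this assay, the read-out lies a number 3.2 percentage points lower from compound 2 to compound 3 (within the scatter), so an aromatic ring on the sulfur does not by itself restore the reading of compound 1. The 1-methyl-1H-tetrazol-5-yl group stands apart from the 1-methyl-1H-imidazol-2-yl group, with the read-out lying a number 24.4 percentage points lower from compound 1 to compound 3 (beyond the scatter). No measurement available here accounts for this gap between the two aromatic rings. The compounds shown leave open whether a different group on this sulfur, such as a triazole ring, a simple methyl or a chain ending in a carboxylic acid, would match or pass compound 1. They also leave open how these readings would stand at other concentrations.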